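The compounds below may be only part of what the source reports. "The series", "measured", "known", "first", "only" and "open" are said of these compounds alone.

Measured compounds:
compound 1 `Cc1cccc(COc2ccc(-c3cc(CN4CCN(Cc5ccc(C(F)(F)F)cc5)CC4)no3)cc2)c1` — 2500 nM
compound 2 `Cc1ccc(COc2ccc(-c3cc(CN4CCN(Cc5ccc(C(F)(F)F)cc5)CC4)no3)cc2)cc1` — 7500 nM

Both were tested in a functional assay on Mahlavu cells (Homo sapiens) for antiproliferative activity, read by sulforhodamine B assay, with a stated time of 72 h; a lower number here means a stronger inhibitor, a higher number a weaker inhibitor. Within the data shown here, compound 2 gives 7500 nM, the higher of the two numbers, with compound 1 at 2500 nM as its only neighbour; the step of a 3.0-fold higher number from compound 1 to compound 2 (0.48 log units; beyond the scatter) is the one step recorded so far, and it rests on moving a methyl group around a ring.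

Compound 3 `N#Cc1ccccc1COc1ccc(-c2cc(CN3CCN(Cc4ccc(C(F)(F)F)cc4)CC3)no2)cc1` is not yet measured. The change from compound 2 is 2-cyanophenyl in place of 4-methylphenyl on a saturated chain carbon bound to an oxygen on an aromatic ring. Among the measured compounds shown here, no measured step involves a nitrile, so the one recorded step bears on it only loosely, by showing that a change on this ring can shift the number modestly.

Compound 3 is therefore expected to fall near the two measured numbers, with the step of a 1.5-fold lower number from compound 2 to compound 3 (0.18 log units; within the scatter) judged uncertain in direction. The estimate for compound 3 is 5000 nM, in a range from 1500 nM to 20000 nM.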

Compound 3, half-maximal inhibitory concentration: 3500 nM
For compound 3 the middle estimate is 1.4-fold (0.15 log units) above the measured one; the measured number falls inside the stated range.
By their numbers in this assay, from the lowest: compounds 1 and 3 (each within the scatter of the next); then compound 2.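

In this assay, the position on the saturated chain carbon bound to an oxygen on an aromatic ring now shows a change of group as well as a moved methyl: 2-cyanophenyl in place of 4-methylphenyl gives a 2.1-fold lower number from compound 2 to compound 3 (0.33 log units; beyond the scatter) and so a modest gain. Set against 3-methylphenyl, the same group gives a 1.4-fold higher number from compound 1 to compound 3 (0.15 log units; within the scatter) and so cannot be told apart from it in this assay, which means a nitrile on this ring does as well here as the better of the two methyl rings. Nothing available accounts for these differences.

Compound 2 and compound 3 differ in both the group and where it sits on the ring, and the compounds shown do not separate those two effects. Going by these compounds, how a ring carrying an amine or a carboxylic acid would read also stays open.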